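Removing One Methoxy Group from Compound 1

A few compounds are considered here, and "the series" means these few. Any claim that something is new, unique, unknown or untested is made for them only; others in the source may bear on it.

Compound 1, `COc1ccc(OC)c(-c2nc(=O)ss2)c1`, was tested in an ADME assay on L02 cells (Homo sapiens) for inhibition, read by MTT assay, with a stated time of 48 h, tested at 100 uM (on this read-out higher numbers stand for more inhibition at the one concentration tested (going by the name of the read-out) and lower numbers for less inhibition), where compound 1 gives 23.7%. Among the measured compounds shown here, this is the lowest of the three numbers measured so far. Compound 2, `O=c1nc(-c2ccc(F)cc2)ss1`, gives 33.7%, a number that lies within the usual scatter of compound 1, so the two cannot be told apart. Compound 3, `Cc1sc(-c2nsc(=O)o2)cc1[N+](=O)[O-]`, gives 53.8%, a number beyond the scatter above compound 1. Compound 4, `COc1cccc(-c2nc(=O)ss2)c1`, has not yet been measured in this assay. It differs from compound 1 in one place: hydrogen in place of methoxy on an aromatic carbon. For the measured compounds named here, no measured pair here shows what such a change does, so only a small step is expected, as a number 1.3 percentage points higher from compound 1 to compound 4 (within the scatter), with no direction beyond the scatter. Compound 4 is therefore expected to give 25%, within 10% to 40%.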

Compound 4, a percentage reported as inhibition, at one concentration (the size of the read-out at that concentration, not a potency): 38.6%
The estimate for compound 4 lay 13.6 percentage points below the measured number, within the range that was stated.
By their numbers in this assay, from the lowest: compounds 1, 2 and 4 (each within the scatter of the next, the first and the last beyond it); then compound 3.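

In this assay, putting hydrogen in place of the methoxy group that sits ortho to a group of 6 heavy atoms gives a number 14.9 percentage points higher from compound 1 to compound 4 (beyond the scatter) and so shows that this one position matters for the read-out. Among the compounds shown here, no earlier pair of compounds differed in a single place, so this is the first direct view of such a change. Nothing measured here explains the step.

Going by these compounds, whether an amine or a hydroxyl group on this carbon would shift the number remains open. So does whether removing the remaining methoxy group would give a similar step.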